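A Benzyl Swap in a Series Without Measurable Cytotoxicity

A few compounds are considered here, and "the series" means these few. Any claim that something is new, unique, unknown or untested is made for them only; others in the source may bear on it.

Three compounds share one core and differ only in the group that sits on a saturated chain carbon bound to an aromatic nitrogen. Compound 1 `CCOC(=O)C1(Cc2ccccc2)CN(c2ccccc2)Cc2nnn(Cc3ccc(OC)cc3)c21` carries a 4-methoxyphenyl there. In an ADME assay on HEL cells (Homo sapiens) for cytotoxicity, read by microscopy, with a stated time of 3 days (on this read-out higher numbers stand for lower toxicity in this test and lower numbers for higher toxicity in this test), compound 1 gives > 100000 nM, which is a limit of the test and not a number. Compound 2 `CCOC(=O)C1(Cc2ccccc2)CN(c2ccccc2)Cc2nnn(Cc3ccc(F)cc3)c21` carries a 4-fluorophenyl instead. In this assay compound 2 gives >= 100000 nM, again a limit. Compound 3 `CCOC(=O)C1(Cc2ccccc2)CN(c2ccccc2)Cc2nnn(Cc3cccc(F)c3)c21` carries a 3-fluorophenyl. In this assay compound 3 gives >= 100000 nM, which is also a limit.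

Among the measured compounds shown here, because every value sits at the limit of > 100000 nM in this assay, at which 1 of the 3 values shown sits, or at the limit of >= 100000 nM in this assay, at which 2 of the 3 values shown sit, none of the measured steps can be read: the step from compound 1 to compound 2 is a step that the two limits leave unreadable from compound 1 to compound 2, the step from compound 1 to compound 3 is a step that the two limits leave unreadable from compound 1 to compound 3, and the step from compound 2 to compound 3 is a step that the two limits leave unreadable from compound 2 to compound 3. Compound 3 therefore stands where all three stand, at the edge of what the test can see.

Compound 4 `CCOC(=O)C1(Cc2ccccc2)CN(c2ccccc2)Cc2nnn(Cc3c(F)cccc3Cl)c21` differs from compound 3 by 2-chloro-6-fluorophenyl in place of 3-fluorophenyl on a saturated chain carbon bound to an aromatic nitrogen. Since the three measured changes on the same carbon all left the read-out at a limit, no step beyond the scatter is expected in this assay. For compound 4 a value of 100000 nM is estimated, within 40000 nM to 200000 nM, and the expected step from compound 3 is a number no higher from compound 3 to compound 4 (the limit leaves the size open).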

Compound 4, minimum cytotoxic concentration: > 100000 nM
Compound 4 gave a limit, no number; the forecaster's own chance of this, stated with the estimate: 80%; the middle value lies on the limit itself.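

In this assay compound 4 gives > 100000 nM, which is a limit of the test and not a number. Its steps from compound 1, compound 2 and compound 3 cannot be read, as both values in each pair are limits. The compounds shown leave open at what concentration any of the four becomes toxic to these cells, and whether the swapped groups differ in this.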